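From cyclopentyl to 3-hydroxypropyl on the shared core

The source may hold more compounds than are shown below. What is called first, only, known or untested is meant among the compounds shown, and "the series" means these compounds.

In a physicochemical assay for lipophilicity, read by HPLC, measured as octanol-water partition, with a stated time of 24 h (a higher number here means a more lipophilic compound, a lower number a more polar compound), compound 2 (`N#Cc1ccc(Nc2nc(NC3CCCC3)c3ccccc3n2)cc1`) stands without a number, its result reading "not determined" (no result reported) in the record. Compound 3 (`N#Cc1ccc(Nc2nc(NCCCO)c3ccccc3n2)cc1`) differs from it by one change (3-hydroxypropyl in place of cyclopentyl on a nitrogen on an aromatic ring) with 3-hydroxypropyl in place of cyclopentyl on a nitrogen on an aromatic ring. A downward step of moderate size is expected in this assay even though compound 2 offers no value to count from. Going by the values given here, compound 1 (`COc1ccc(Nc2nc(NCCCO)c3ccccc3n2)cc1`) carries the same 3-hydroxypropyl and gives 2.54 as the only number at hand. Compound 3 is expected at 2.5 within an estimated range from 2 to 3 once measured.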

Compound 3, partition coefficient: 2.84
For compound 3 the middle estimate is 0.34 log units below the measured one; the measured number falls inside the stated range.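

Cyano in place of methoxy on an aromatic carbon, with 3-hydroxypropyl kept on the nitrogen, gives in this assay a number 0.30 log units higher from compound 1 to compound 3 (within the scatter) and so leaves the two compounds indistinguishable on this read-out. Compound 2 has no number, so the step from cyclopentyl to 3-hydroxypropyl cannot be read. Nothing available bears on a reason for this result. From the compounds shown here alone, what an amine, a carboxylic acid or a longer chain in place of 3-hydroxypropyl would give on this nitrogen stays open.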